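The source may report more compounds than this note shows. Statements on the series, on what has been measured and on what is new or still open speak of the compounds shown alone.

Measured compounds:
- compound 1 `O=C(Nc1cccc2cn[nH]c12)N1CCN(Cc2cccc(Oc3ccc(Cl)cc3)c2)CC1` gives 6000 nM in an assay on isolated protein for inhibition of Fatty-acid amide hydrolase 1 (Rattus norvegicus), with a stated time of 60 min; a higher number here means a weaker inhibitor, a lower number a stronger inhibitor
- compound 2 `O=C(Nc1cncc2ccccc12)N1CCN(Cc2cccc(Oc3ccc(Cl)cc3)c2)CC1` gives 8.3 nM in this assay
- compound 3 `O=C(Nc1noc2cnccc12)N1CCN(Cc2cccc(Oc3ccc(Cl)cc3)c2)CC1` gives 0.7 nM in this assay

Among these three, compound 2 stands second highest in this assay: its nearest neighbour is compound 3, reached by a 12-fold lower number from compound 2 to compound 3 (1.07 log units; beyond the scatter), and its furthest is compound 1, separated by a 720-fold lower number from compound 1 to compound 2 (2.86 log units; beyond the scatter). Compound 4 `O=C(Nc1noc2ccncc12)N1CCN(Cc2cccc(Oc3ccc(Cl)cc3)c2)CC1` is not yet measured. It differs from compound 2 by a group of 9 heavy atoms (6 carbon, 2 nitrogen, 1 oxygen; one five-membered aromatic ring with 2 hetero atoms, one six-membered aromatic ring with 1 hetero atom) in place of a group of 10 heavy atoms (9 carbon, 1 nitrogen; one six-membered aromatic ring of carbon only, one six-membered aromatic ring with 1 hetero atom), on an amide-type nitrogen. The group that enters has the same counted composition as the group in compound 3, so the measured step that bears most directly on this change is a 12-fold lower number from compound 2 to compound 3 (1.07 log units; beyond the scatter), a large drop. The step of an 8600-fold lower number from compound 1 to compound 3 (3.93 log units; beyond the scatter) points the same way but starts from a different group and is less directly comparable. On this basis the number for compound 4 in this assay is expected to come out lower than that of compound 2, by a step of roughly the size seen for compound 3, though the two entering groups are not the same, so the expected shift is a 5.5-fold lower number from compound 2 to compound 4 (0.74 log units; beyond the scatter). Compound 4 is thus estimated at 1.5 nM, with a range from 0.4 nM to 6 nM.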

Compound 4, half-maximal inhibitory concentration: 2200 nM
Compound 4: the middle estimate sits 1500-fold (3.17 log units) below what was measured; measured number outside the range, above it.
By their numbers in this assay, from the lowest: compound 3; then compound 2; then compound 4; then compound 1.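

In this assay, two groups with the same counted atoms and rings, differing only in how those atoms are arranged, lie far apart at this amide-type nitrogen: there is a 3100-fold higher number from compound 3 to compound 4 (3.50 log units; beyond the scatter), so the counted composition of the entering group does not settle the outcome here. Putting this group in place of isoquinolin-4-yl gives a 270-fold higher number from compound 2 to compound 4 (2.42 log units; beyond the scatter), the opposite direction to the drop seen for the group in compound 3, while the comparison with 1H-indazol-7-yl gives a 2.7-fold lower number from compound 1 to compound 4 (0.44 log units; beyond the scatter), a modest step that still lies beyond the scatter. No measurement is available that accounts for the difference between these two arrangements.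

The compounds shown leave open how single-ring groups such as phenyl or pyridin-3-yl would behave on this amide-type nitrogen, and so how much of either fused pair of rings this place in the molecule requires. They also leave open whether the wide gap between compound 3 and compound 4 would persist if the chlorine of the shared core gave way to fluorine or a methoxy group.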